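The source may report more compounds than this note shows. Statements on the series, on what has been measured and on what is new or still open speak of the compounds shown alone.

Compound 1, `CC(Sc1nnc(-c2ccncc2)s1)C(=O)Nc1ccc(Cl)cc1Cl`: in an ADME assay on HepG2 cells (Homo sapiens) for cytotoxicity, with a stated time of 3 days (a lower number here means that less compound is tolerated, a higher number that more compound is tolerated), compound 1 gives > 50000 nM, a limit of the assay.
Compound 2, `O=C(CCSc1nnc(-c2ccncc2)s1)Nc1ccccc1`: in this assay compound 2 gives > 50000 nM, again a limit.
Compound 3, `O=C(CSc1nnc(-c2ccncc2)s1)Nc1ccc(Cl)cc1Cl`: in this assay compound 3 gives "not determined" (no result reported).

Compound 3 therefore stands nowhere on the numbers shown: there is no single value for it, and the only other entries are the limit of > 50000 nM in this assay, at which 2 of the 3 values shown sit, so the series offers no measured step at all against which a change can be weighed. Compound 4, `O=C(CSc1nnc(-c2ccncc2)s1)NCc1ccccc1`, is the compound still to be tested. It differs from compound 3 in one place: benzyl in place of 2,4-dichlorophenyl on an amide-type nitrogen. Among the measured compounds shown here, since no step between measured compounds exists, the size of the change from compound 3 to compound 4 in this assay cannot be read off; the best that can be said is that the two measured analogues both sit at the limit, and no difference beyond the scatter is expected here. Compound 4 is therefore expected to give about 60000 nM, within 20000 nM to 200000 nM, most likely reported as a limit.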

Compound 4, half-maximal cytotoxic concentration: 17700 nM
For compound 4 the middle estimate is 3.4-fold (0.53 log units) above the measured one; the measured number lies below the stated range.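

In this assay compound 3 gives "not determined" (no result reported) and compound 4 gives 17700 nM, so no step can be read between them. The compounds shown leave open what benzyl in place of 2,4-dichlorophenyl on the amide-type nitrogen does to the half-maximal cytotoxic concentration.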